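The compounds below may be only part of what the source reports. "The series", "measured", "known", "first", "only" and "open" are said of these compounds alone.

Of the compounds shown here, two carry numbers so far. In a functional assay on the whole organism (strain Charles-Foster albino) for inhibition, with Rattus norvegicus as the target, read by paw edema, at a dose of 50 mg/kg by the oral route (on this read-out higher numbers stand for more inhibition at the one dose given (going by the name of the read-out) and lower numbers for less inhibition), compound 1 `O=C1CSC(c2ccccc2)N1n1c(CSc2nnc(-c3ccncc3)o2)nc2ccccc2c1=O` gives 30.1%, and in this assay compound 2 `O=c1c2cc(Br)ccc2nc(CSc2nnc(-c3ccncc3)o2)n1/N=C/c1ccc(O)cc1` gives 22.3%. Compound 2 thus holds the lower of the two numbers, but its gap to compound 1 lies within the scatter, so no order between them can be claimed. Compound 3 `O=c1c2ccccc2nc(CSc2nnc(-c3ccncc3)o2)n1/N=C/c1ccc(O)cc1` is not yet measured; it differs from compound 2 in one place: hydrogen in place of bromo on an aromatic carbon. Among the compounds with values here, no measured pair shows what this change does, so no step beyond the scatter is expected in this assay. Compound 3 is estimated at 22%, with a range from 10% to 35%. The expected step is a number 0.3 percentage points lower from compound 2 to compound 3 (within the scatter).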

Compound 3, a percentage reported as inhibition, in the whole organism at one dose (the size of the read-out at that dose, not a potency): 18.2%
Estimate against measurement, compound 3: 3.8 percentage points above; the measured number falls inside the stated range.
By their numbers in this assay, from the lowest: compounds 3, 2 and 1 (each within the scatter of the next, the first and the last beyond it).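

In this assay, hydrogen in place of bromo on the aromatic carbon gives a number 4.1 percentage points lower from compound 2 to compound 3 (within the scatter), so no effect of this change can be read at this position. Within the data shown here, on the aromatic nitrogen, the group with the six-membered aromatic ring in place of the group with the five-membered non-aromatic ring gives a number 11.9 percentage points lower from compound 1 to compound 3 (beyond the scatter), the first step beyond the scatter. No measurement at hand offers a reason for either step.

Open, on these data alone, is what an amine or a carboxylic acid on that aromatic carbon would do. Also open, as far as these compounds go, is whether the step on the aromatic nitrogen holds with bromo present.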